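The source may report more compounds than this note shows. Statements on the series, on what has been measured and on what is new or still open speak of the compounds shown alone.

Compound 1, `O=C(O)[C@H]1NCC=C[C@H]1O`: 17%
Compound 2, `O=C(O)[C@@H]1NC[C@@H](O)[C@H](O)[C@@H]1O`: 0.8%
Compound 3, `O=C(O)[C@H]1NC[C@@H](O)[C@H](O)[C@@H]1O`: 42%

In an assay on isolated protein for inhibition of cytosolic endo-beta-N-acetylglucosaminidase (Homo sapiens), tested at 1000 uM (a higher number here means more inhibition at the concentration tested (going by the name of the read-out), a lower number less inhibition), compound 3 stands highest of the three, above both compound 1 and compound 2 by margins beyond the scatter. Among the compounds with values here, the only step between measured compounds is a number 41.2 percentage points higher from compound 2 to compound 3 (beyond the scatter), and the fact that compounds 2 and 3 differ only in the configuration as drawn shows how much a single inversion at a ring carbon can move this read-out. Compound 4, `O=C(O)[C@@H]1NC[C@H](O)[C@H](O)[C@H]1O`, is a further stereoisomer: the two compounds have the same atoms and bonds and differ only in configuration as drawn: 3 of 4 stereo elements differ; a stereocentre at a saturated ring carbon is drawn S in compound 3 and R in compound 4; a stereocentre at a saturated ring carbon is drawn R in compound 3 and S in compound 4; a stereocentre at a saturated ring carbon is drawn R in compound 3 and S in compound 4. This change undoes the inversion that separated compound 2 from compound 3 and adds two more, so the step from compound 2 to compound 3 bears on it directly and argues for a large fall. Compound 4 is therefore expected to show a number 32 percentage points lower from compound 3 to compound 4 (beyond the scatter) in this assay, with an estimate of 10% ranging from 0% to 40%.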

Compound 4, a percentage reported as inhibition, at one concentration (the size of the read-out at that concentration, not a potency): 39%
The estimate for compound 4 lay 29 percentage points below the measured number; measured number inside the range.
By their numbers in this assay, from the lowest: compound 2; then compound 1; then compounds 4 and 3 (each within the scatter of the next).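

In this assay the result is a number 3 percentage points lower from compound 3 to compound 4 (within the scatter), so changing three stereocentres at once can leave the read-out where it stood, while the single inversion seen earlier moved it sharply. That inversion therefore does not settle the read-out alone, since two other ring stereocentres give a number 38.2 percentage points higher from compound 2 to compound 4 (beyond the scatter).

Which of those two centres carries this step remains open. So does how an amide in place of the carboxylic acid would read in this assay.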